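The source may hold more compounds than are shown below. What is called first, only, known or untested is meant among the compounds shown, and "the series" means these compounds.

Measured so far:
compound 1, `Nc1nn(C(=O)Nc2ccc(Cc3ccccc3)cc2)c2ccccc12`: 39600 nM
compound 2, `Nc1nn(C(=O)Nc2ccc(Cc3ccccc3)cc2)c2ccc(Cl)cc12`: 44000 nM

Both numbers come from a functional assay on BT-549 cells (Homo sapiens) for antiproliferative activity, read by sulforhodamine B assay, with a stated time of 48 h; a lower number here means a stronger inhibitor of growth, a higher number a weaker inhibitor of growth. For the measured compounds named here, compound 2 holds the higher of the two, and compound 1 is its only neighbour. The step of a 1.1-fold higher number from compound 1 to compound 2 (0.05 log units; within the scatter) is within the scatter. Compound 3, `Nc1ccc2c(c1)c(N)nn2C(=O)Nc1ccc(Cc2ccccc2)cc1`, is not yet measured; the change is amino in place of chloro on an aromatic carbon. Going by the values given here, only one measured step touches that aromatic carbon, a 1.1-fold higher number from compound 1 to compound 2 (0.05 log units; within the scatter), and it stayed within the scatter, so a similar outcome is expected here, with no other step to draw on. For compound 3 in this assay the expected step is a 1.1-fold lower number from compound 2 to compound 3 (0.04 log units; within the scatter). The estimate for compound 3 is 40000 nM, range 15000 nM to 110000 nM.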

Compound 3, concentration for total growth inhibition: 33500 nM
Estimate against measurement, compound 3: 1.2-fold (0.08 log units) above, and the stated range covers the measured number.
By their numbers in this assay, from the lowest: compounds 3, 1 and 2 (each within the scatter of the next).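

In this assay, amino at this aromatic carbon gives no separation from either chloro or hydrogen: the readings are a 1.3-fold lower number from compound 2 to compound 3 (0.12 log units; within the scatter) and a 1.2-fold lower number from compound 1 to compound 3 (0.07 log units; within the scatter), both within the scatter. Three different substituents at this position now fall within the scatter, including amino with its hydrogen-bond donor and acceptor, which chloro lacks. No supporting measurement is available to explain this reading. As far as these compounds go, whether a carboxylic acid, a methoxy group or a longer chain at this carbon would move the number beyond the scatter remains open. From the compounds shown here alone, the effect of changes elsewhere on the shared core also remains open.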